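The source may report more compounds than this note shows. Statements on the series, on what has been measured and on what is new or still open speak of the compounds shown alone.

Compound 1 `FC(F)(F)c1ccc(CSc2nc(Nc3ccccc3)c3ccccc3n2)cc1` in a functional assay on MCF7 cells (Homo sapiens) for cytotoxicity, read by MTT assay, with a stated time of 72 h (on this read-out higher numbers stand for weaker inhibition and lower numbers for stronger inhibition), gives 44000 nM.
Compound 2 `COc1ccccc1Nc1nc(SCc2ccc(C(F)(F)F)cc2)nc2ccccc12` gives only a limit, > 50000 nM, and not a number.
Compound 3 `FC(F)(F)c1ccc(CSc2nc(Nc3cccc(C(F)(F)F)c3)c3ccccc3n2)cc1` gives 15300 nM.

Compound 3 therefore carries the lowest number shown; the nearest measured neighbour is reached by a 2.9-fold lower number from compound 1 to compound 3 (0.46 log units; beyond the scatter). Compound 4 `O=[N+]([O-])c1cccc(Nc2nc(SCc3ccc(C(F)(F)F)cc3)nc3ccccc23)c1` differs from compound 3 by nitro in place of trifluoromethyl on an aromatic carbon. The measured steps that touch this ring are a 2.9-fold lower number from compound 1 to compound 3 (0.46 log units; beyond the scatter) and an at least 3.2-fold lower number from compound 2 to compound 3 (0.51 log units; beyond the scatter), both modest, and one of them rests on a limit (the limit of > 50000 nM in this assay, at which 1 of the 3 values shown sits). Neither step exchanges nitro for trifluoromethyl, so they give no direct guide. The expected step is a 1.0-fold lower number from compound 3 to compound 4 (0.01 log units; within the scatter), meaning no change beyond the usual scatter. Compound 4 is accordingly estimated at 15000 nM, with a range from 6000 nM to 40000 nM.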

Compound 4, half-maximal inhibitory concentration: > 50000 nM
Compound 4 gave a limit, no number; the forecaster's own chance of this, stated with the estimate: 10%; middle value at least 3.3-fold (0.52 log units) away from the limit.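

In this assay, this position does not accept just any group: exchanging trifluoromethyl for nitro gives an at least 3.2-fold higher number from compound 3 to compound 4 (0.51 log units; beyond the scatter), so the gain seen with compound 3 is not kept. Set against hydrogen at the same place, nitro gives an at least 1.1-fold higher number from compound 1 to compound 4 (0.05 log units; that floor lies within the scatter), so it shows no measurable gain. The step linking compound 2 and compound 4 cannot be read, and the result for compound 4 is a limit, not a number: the limit of > 50000 nM in this assay, at which 2 of the 4 values shown sit.

Going by these compounds, whether a methyl group or a chlorine atom at this place would keep the activity of compound 3 remains open. So does how far compound 4 lies beyond its limit.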